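This account rests on a few compounds, and the source may have more. Where it says the series, first, only, none or still open, it means among the compounds named here.

Series notes. Compound 1 `CC(C)(C)CCc1cc(C(F)(F)F)ccc1CNC(=O)Nc1cccc2[nH]ncc12` gives 4.3 nM in a functional assay for antagonist activity at transient receptor potential cation channel subfamily V member 1 (Homo sapiens); a lower number here means a stronger inhibitor, a higher number a weaker inhibitor. Compound 2 `O=C(NCc1ccc(C(F)(F)F)cc1CCc1ccccc1)Nc1cccc2[nH]ncc12` gives 8 nM in this assay. Going by the values given here, the one step measured so far, a 1.9-fold higher number from compound 1 to compound 2 (0.27 log units; within the scatter), swaps tert-butyl for phenyl on a saturated chain carbon, two bonds along the chain from an aromatic carbon, and does not move the number beyond the scatter. Among the compounds with values here, compound 2 thus holds the highest of the two numbers so far, with compound 1 nearest and within the scatter of it; on these two values no order between them can be claimed.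

Compound 3 `COCCCc1cc(C(F)(F)F)ccc1CNC(=O)Nc1cccc2[nH]ncc12` is the next compound at the same place: methoxymethyl in place of phenyl on a saturated chain carbon, two bonds along the chain from an aromatic carbon. Within the data shown here, only one measured step bears on this position, and it was within the scatter, but it exchanged one ring-free or ring-bearing carbon group for another; no step so far brings an oxygen-bearing chain into this place, so the measured data give no direct guide. Among the measured compounds shown here, the expectation for compound 3 is a modest step to a higher number, a 2.5-fold higher number from compound 2 to compound 3 (0.40 log units; beyond the scatter), because the nearest precedent, a 1.9-fold higher number from compound 1 to compound 2 (0.27 log units; within the scatter), already ran toward higher numbers, if only within the scatter. Compound 3 is therefore estimated at 20 nM, within a range of 6 nM to 70 nM.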

Compound 3, half-maximal inhibitory concentration: 8 nM
For compound 3 the middle estimate is 2.5-fold (0.40 log units) above the measured one; measured number inside the range.
By their numbers in this assay, from the lowest: compounds 1, 2 and 3 (each within the scatter of the next).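

Bringing an oxygen-bearing chain into this place, with methoxymethyl in place of phenyl on a saturated chain carbon, two bonds along the chain from an aromatic carbon, gives no change at the digits printed from compound 2 to compound 3 (within the scatter) in this assay. Set against the ring-free carbon group of compound 1, the same chain gives a 1.9-fold higher number from compound 1 to compound 3 (0.27 log units; within the scatter), so compounds 1, 2 and 3 all lie within the scatter of one another, and a hydrogen-bond acceptor entering the chain, with the phenyl ring gone, leaves the number unmoved beyond that scatter. No information is available on why these three different groups give values this close.

Every group shown at this place is uncharged and none separates from the others beyond the scatter, which leaves open whether an amine, a carboxylic acid or a chain longer than 3-methoxypropyl would stay within it. All three compounds also share the rest of their structure, so whether the same freedom at this place would hold on a different core remains an open question for the series.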